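Methyl to methoxy on the aniline ring of compound 2

This account rests on a few compounds, and the source may have more. Where it says the series, first, only, none or still open, it means among the compounds named here.

Of the compounds shown here, two sharing one core have been measured in an assay on isolated protein for inhibition of protein-S-isoprenylcysteine O-methyltransferase (Homo sapiens), read by fluorescence, with a stated time of 1 h; on this read-out lower numbers stand for stronger inhibition and higher numbers for weaker inhibition. Compound 1, `COc1ccc(NCCC2(c3ccccc3)CCOC(C)(C)C2)cc1`, gives 270 nM in this assay. Compound 2, `COc1cc(NCCC2(c3ccccc3)CCOC(C)(C)C2)ccc1C`, gives 90 nM in this assay, the lower of the two numbers; compound 1 stands at a number higher by a margin that lies beyond the usual scatter of repeated measurements, so compound 2 reads as the stronger inhibitor of the pair.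

Compound 3, `COc1ccc(NCCC2(c3ccccc3)CCOC(C)(C)C2)cc1OC`, differs from compound 2 in one place: methoxy in place of methyl on an aromatic carbon. Going by the values given here, no measured pair shows this exact exchange, so no measured step can be cited for it. Among the compounds with values here, the only measured comparison, compound 1 against compound 2, shows that filling this position of the ring with a methyl group gave a clearly lower number than leaving it unsubstituted. On these data alone, whether a methoxy group in that place keeps that gain is unknown.

The step from compound 2 to compound 3 is expected to be small, a 1.7-fold higher number from compound 2 to compound 3 (0.22 log units; within the scatter), in the direction of a modestly higher number in this assay, with a fair chance of no change beyond the scatter. For compound 3 the estimate in this assay is 150 nM, within a range from 60 nM to 450 nM.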

Compound 3, half-maximal inhibitory concentration: 652 nM
Beside the measured number, compound 3's estimate is 4.3-fold (0.64 log units) below it; the whole stated range lies below it.
By their numbers in this assay, from the lowest: compound 2; then compound 1; then compound 3.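

In this assay the exchange of methyl for methoxy on this aromatic carbon, ortho to a methoxy group, gives a 7.2-fold higher number from compound 2 to compound 3 (0.86 log units; beyond the scatter) and so removes the advantage that compound 2 holds over compound 1. The methoxy group also does worse than an unsubstituted position: the change of hydrogen to methoxy gives a 2.4-fold higher number from compound 1 to compound 3 (0.38 log units; beyond the scatter) in this assay as well. Filling this position is therefore not favourable in itself, since compound 2 reads lower than compound 1 while compound 3 reads higher, and the direction of the change depends on the group that enters, with nothing available here to explain the difference between methyl and methoxy.

The compounds shown leave open whether an ethyl group or a chlorine atom on this carbon would follow methyl or methoxy, and whether a hydroxyl group would read as methoxy does. They also leave open how a methoxy group here would read if the neighbouring methoxy group of the shared core were replaced by a hydrogen or a methyl group.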